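Chloro Analog of a Shared Core: Expected Cytotoxicity

The source may hold more compounds than are shown below. What is called first, only, known or untested is meant among the compounds shown, and "the series" means these compounds.

Of the compounds shown here, three built on one core have been tested in an ADME assay on THP-1 cells (Homo sapiens) for cytotoxicity, read by MTT assay; a lower number here means that less compound is tolerated, a higher number that more compound is tolerated. Compound 1 `Cc1nc(-c2cccnc2)sc1-c1nnc(-c2ccc(Br)cc2)o1` carries a bromo group on the phenyl ring; in this assay compound 1 gives > 100 ug/mL, which is a limit of the assay and not a number. Compound 2 `Cc1nc(-c2cccnc2)sc1-c1nnc(-c2ccc([N+](=O)[O-])cc2)o1` carries a nitro group on that aromatic carbon; in this assay compound 2 gives > 100 ug/mL, again only a limit. Compound 3 `Cc1nc(-c2cccnc2)sc1-c1nnc(-c2ccccc2)o1` carries hydrogen there; in this assay compound 3 gives > 100 ug/mL, also a limit. Compound 3 thus stands exactly where the other two stand, at the limit of > 100 ug/mL in this assay, at which 3 of the 3 values shown sit, so the steps a step that the two limits leave unreadable from compound 1 to compound 2, a step that the two limits leave unreadable from compound 1 to compound 3 and a step that the two limits leave unreadable from compound 2 to compound 3 cannot be sized. Compound 4 `Cc1nc(-c2cccnc2)sc1-c1nnc(-c2ccc(Cl)cc2)o1` differs from compound 3 by chloro in place of hydrogen on an aromatic carbon, para to a large group. The nearest measured comparison is compound 1, which in this assay gives > 100 ug/mL, a limit. The step that the limit leaves unreadable from compound 3 to compound 4 is expected to show nothing readable. Compound 4 is expected at 150 ug/mL, between 100 ug/mL and 300 ug/mL, most likely reported only as a limit.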

Compound 4, half-maximal cytotoxic concentration: > 100 ug/mL
Compound 4: a limit, no number; the forecaster's own chance of this, stated with the estimate: 90%; the middle value is on the limit's open side.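

Among these compounds, compound 4 gives only a limit, like compound 1, compound 2 and compound 3, so no step among them can be read in this assay: the limit of > 100 ug/mL in this assay, at which 4 of the 4 values shown sit. The compounds shown leave open how much of each is actually tolerated, and whether hydrogen, bromo, nitro or chloro makes any difference.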